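The compounds below may be only part of what the source reports. "The series", "measured", "known", "first", "only" and "open" are said of these compounds alone.

In a functional assay on DU-145 cells (Homo sapiens) for antiproliferative activity, read by propidium iodide staining, with a stated time of 96 h (a lower number here means a stronger inhibitor, a higher number a weaker inhibitor), compound 1 `CC(O)(CSc1ccc(F)cc1)C(=O)Nc1cccc(S(F)(F)(F)(F)F)c1` gives 38500 nM and compound 2 `CC(O)(CSc1cccc(C(F)(F)F)c1)C(=O)Nc1cccc(S(F)(F)(F)(F)F)c1` gives 19100 nM. The change between them is 3-(trifluoromethyl)phenyl in place of 4-fluorophenyl on a sulfur and it made a 2.0-fold lower number from compound 1 to compound 2 (0.30 log units; within the scatter). Compound 3 `CC(O)(CS(=O)(=O)c1ccc(F)cc1)C(=O)Nc1cccc(S(F)(F)(F)(F)F)c1` gives 48800 nM in this assay, the highest of the three numbers; its gap to compound 1 is within the scatter, its gap to compound 2 beyond it. How the core of compound 3 differs from the core of compound 1 is not broken down here.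

Compound 4 `CC(O)(CS(=O)(=O)c1cccc(C(F)(F)F)c1)C(=O)Nc1cccc(S(F)(F)(F)(F)F)c1` is not yet measured; from compound 3 it differs by 3-(trifluoromethyl)phenyl in place of 4-fluorophenyl on a sulfonyl sulfur. Among the measured compounds shown here, this is the same kind of change as the one between compound 1 and compound 2, but not the same: the place is a sulfonyl sulfur rather than a sulfur, while in both cases the other neighbour is a saturated chain carbon. In this assay, for the measured compounds named here, the expected step is a 2.0-fold lower number from compound 3 to compound 4 (0.29 log units; within the scatter), resting on a 2.0-fold lower number from compound 1 to compound 2 (0.30 log units; within the scatter) and carried over to the other place, where no measured pair yet confirms it. Compound 4 is estimated at 25000 nM, with a range from 12000 nM to 60000 nM.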

Compound 4, half-maximal inhibitory concentration: 37300 nM
Compound 4: the middle estimate sits 1.5-fold (0.17 log units) below what was measured; measured number inside the range.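

In this assay, the change from 4-fluorophenyl to 3-(trifluoromethyl)phenyl on a sulfonyl sulfur gives a 1.3-fold lower number from compound 3 to compound 4 (0.12 log units; within the scatter), and this step does not differ from the one seen on a sulfur: the same change on two cores in this assay, a 2.0-fold lower number (0.30 log units; within the scatter) from compound 1 to compound 2 and a 1.3-fold lower number (0.12 log units; within the scatter) from compound 3 to compound 4, 1.5-fold (0.19 log units) apart, within the scatter of two such steps. Within this one pair of cores, the change therefore carries over without a detectable difference in step size. This does not show that the change itself moves the number, since each step lies within the scatter, and two cores with one pair of groups in a single assay cannot establish that the step would hold on other cores.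

The compounds shown leave open whether a different kind of group on the sulfur or sulfonyl sulfur, such as a phenyl ring bearing a carboxylic acid or an amine, would give a step beyond the scatter. They also leave open whether replacing the hydroxyl group on the shared chain with an amine would alter the numbers in this assay.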